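The source may hold more compounds than are shown below. What is called first, only, known or untested is meant among the compounds shown, and "the series" means these compounds.

Series notes. The shared core carries two 4-methoxyphenyl groups and is varied at one aromatic carbon. Compound 1 `COc1ccc(-c2nc(CNC(=O)c3cccnc3)sc2-c2ccc(OC)cc2)cc1` is measured in a functional assay with Oryctolagus cuniculus as the target (on this read-out lower numbers stand for stronger inhibition and higher numbers for weaker inhibition), and gives 25 nM. Compound 2 `COc1ccc(-c2nc(C(=O)N3CCCCC3CCO)sc2-c2ccc(OC)cc2)cc1`, which carries a different group at the same aromatic carbon, gives in this assay a value of 45 nM. Compound 1 has the lower of the two numbers, but the gap to compound 2 is within the scatter, so the two values show no difference that can be read.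

Compound 3 `COc1ccc(-c2nc(C3=CCN(C)CC3)sc2-c2ccc(OC)cc2)cc1` has not yet been measured. Relative to compound 1 the change is a group of 7 heavy atoms (6 carbon, 1 nitrogen; one six-membered non-aromatic ring with 1 hetero atom) in place of a group of 10 heavy atoms (7 carbon, 2 nitrogen, 1 oxygen; one six-membered aromatic ring with 1 hetero atom), on an aromatic carbon. The group that leaves carries the amide hydrogen and the pyridine; the group that enters is a six-membered non-aromatic ring with one nitrogen and no hydrogen-bond donor. For the measured compounds named here, no measured pair shows what a change of this kind does, so the expectation rests on the fact that compound 1 and compound 2 both sit at similar values with unlike groups at this carbon.

For compound 3 in this assay a small weakening is expected, a 2.4-fold higher number from compound 1 to compound 3 (0.38 log units; beyond the scatter), of a size close to the scatter. The estimated value for compound 3 is 60 nM, with an expected range from 15 nM to 250 nM.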

Compound 3, half-maximal inhibitory concentration: < 10 nM
Compound 3 gave a limit, no number (the forecaster's own chance of this, stated with the estimate: 5%); at least 6.0-fold (0.77 log units) between middle value and limit.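

Compound 3 stands at < 10 nM in this assay, which is a limit of the assay and not a number. Compounds 1 and 2 left it unclear whether the group on this aromatic carbon could move the read-out at all, since their two values could not be told apart; the exchange of (((pyridin-3-yl)carbonyl)amino)methyl for the six-membered non-aromatic ring with one nitrogen now gives an at least 2.5-fold lower number from compound 1 to compound 3 (0.39 log units; beyond the scatter), so this position does register a change of group. The amide hydrogen and the pyridine of compound 1 are also not required for strong inhibition here, as compound 3 carries neither and has no hydrogen-bond donor in the entering group.

From the compounds shown here alone, how large the step really is stays open, as the reading for compound 3 is cut off: the limit of < 10 nM in this assay, at which 1 of the 3 values shown sits. Also open, going by these compounds, is which feature of the entering group matters, for instance the methyl on the ring nitrogen, the ring double bond or the ring itself, and how an open-chain amine such as dimethylaminomethyl or a carboxylic acid would read on this carbon.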